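The source may hold more compounds than are shown below. What is called first, only, known or untested is meant among the compounds shown, and "the series" means these compounds.

Measured so far in a functional assay on HT29-AK cells (Homo sapiens) for cytotoxicity, read by MTT assay, with a stated time of 48 h; on this read-out lower numbers stand for stronger inhibition and higher numbers for weaker inhibition:
- compound 1, `Fc1cccc(-c2nc(Nc3ccccc3F)c3cc(F)ccc3n2)c1`, gives only a limit of this assay, > 50000 nM
- compound 2, `Fc1cccc(-c2nc(Nc3ccc(Cl)cc3)c3cc(F)ccc3n2)c1`, gives 40300 nM
- compound 3, `Fc1cccc(-c2nc(Nc3ccc(Br)cc3)c3cc(F)ccc3n2)c1`, gives only a limit of this assay, > 50000 nM

Compound 3 therefore stands at the limit of > 50000 nM in this assay, at which 2 of the 3 values shown sit, and its value is a limit rather than a number. Compound 4, `Fc1cccc(-c2nc(Nc3cccc(Br)c3)c3cc(F)ccc3n2)c1`, differs from compound 3 by 3-bromophenyl in place of 4-bromophenyl on a nitrogen on an aromatic ring. Among the compounds with values here, no measured step moves a bromo from one position to another on this phenyl ring while keeping everything else fixed. The nearest comparisons are an at least 1.2-fold higher number from compound 2 to compound 3 (0.09 log units; that floor lies within the scatter), an at least 1.2-fold lower number from compound 1 to compound 2 (0.09 log units; that floor lies within the scatter) and a step that the two limits leave unreadable from compound 1 to compound 3, all of which are small or unreadable and none of which leaves the scatter. On this basis the step of an at least 1.1-fold lower number from compound 3 to compound 4 (0.04 log units; that floor lies within the scatter) is expected to be no larger than the scatter, with a fair chance that compound 4 again returns only a limit. The value of compound 4 in this assay is estimated at 45000 nM, within a range from 20000 nM to 100000 nM.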

Compound 4, half-maximal inhibitory concentration: > 50000 nM
Compound 4: no number, only a limit; the forecaster's own chance of this, stated with the estimate: 60%; middle value at least 1.1-fold (0.04 log units) from the limit.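

In this assay compound 4 gives only a limit, > 50000 nM, so moving the bromo from 4-bromophenyl to 3-bromophenyl on this nitrogen does not bring a number into view. Within the data shown here, the steps to compound 4 from compound 3 and from compound 1 join two limits and cannot be read, and the one step that can be read is an at least 1.2-fold higher number from compound 2 to compound 4 (0.09 log units; that floor lies within the scatter). The position of the bromo on this phenyl ring therefore has no readable effect in this assay, and the result adds one more compound at the limit: the limit of > 50000 nM in this assay, at which 3 of the 4 values shown sit.

As far as these compounds go, how far the true values of compound 1, compound 3 and compound 4 lie past this limit remains open, so a difference between the bromo positions could be hidden there. Also open, from the compounds shown here alone, is whether an amine or a carboxylic acid on this phenyl ring would give a clearly lower number on the shared core.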